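The compounds below may be only part of what the source reports. "The series", "measured", "known", "first", "only" and "open" are said of these compounds alone.

Measured so far:
- compound 1 `CN1C(=O)[C@@H](N)CSSC(C)(C)[C@H](C(N)=O)NC(=O)[C@H](CC(=O)O)NC(=O)CNC(=O)[C@@H]1CCCN=C(N)N`: 200 nM
- compound 2 `CC(=O)N[C@H]1CSSC(C)(C)[C@H](C(=O)O)NC(=O)[C@H](CC(=O)O)NC(=O)CNC(=O)[C@H](CCCN=C(N)N)N(C)C1=O`: 80 nM

In a functional assay (plasma) for inhibition, with Canis familiaris (Canis lupus familiaris) as the target (on this read-out lower numbers stand for stronger inhibition and higher numbers for weaker inhibition), compound 2 has the lower of the two numbers at 80 nM, and the gap to compound 1 at 200 nM lies beyond the usual scatter. Compound 2 is therefore the stronger inhibitor of this pair.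

Compound 3 `CN1C(=O)[C@@H](N)CSSC(C)(C)[C@H](C(=O)O)NC(=O)[C@H](CC(=O)O)NC(=O)CNC(=O)[C@@H]1CCCN=C(N)N` has not yet been measured. Its difference from compound 2 is hydrogen in place of acetyl on an amine nitrogen. In words, this is hydrogen in place of acetyl on an amine nitrogen, or acetamido to amino when cut one bond further out.

For the measured compounds named here, no measured step shows this change, so the expectation rests only on the two values in hand. With compound 2 at 80 nM as the starting point and compound 1 at 200 nM as the only other reference, a small move towards weaker inhibition is expected, possibly not beyond the scatter. The expected step is a 1.6-fold higher number from compound 2 to compound 3 (0.21 log units; within the scatter).

For compound 3 the estimated value in this assay is 130 nM, with an expected range of 50 nM to 350 nM.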

Compound 3, half-maximal inhibitory concentration: 120 nM
Estimate against measurement, compound 3: 1.1-fold (0.03 log units) above; measured number inside the range.
By their numbers in this assay, from the lowest: compounds 2, 3 and 1 (each within the scatter of the next, the first and the last beyond it).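

In this assay, hydrogen in place of acetyl on the amine nitrogen gives a 1.5-fold higher number from compound 2 to compound 3 (0.18 log units; within the scatter) and so does not separate acetamido from amino on this read-out. Hydroxy in place of amino on a carbonyl carbon gives a 1.7-fold lower number from compound 1 to compound 3 (0.22 log units; within the scatter) and so does not separate the carboxylic acid from the primary carboxamide at this place either, which means that each of these two places now has a single step of its own in the series, and neither step by itself lies beyond the scatter. Nothing on hand gives a measured reason for the size of either step.

Open, from the compounds shown here alone, is whether a larger group on the same amine nitrogen, such as a butyryl chain, a methanesulfonyl group or a plain methyl, reads apart from amino and acetamido, and whether a methyl ester on that carbonyl carbon reads apart from the acid and the primary carboxamide. Also open, going by these compounds, is how acetamido reads when paired with the primary carboxamide on the shared core, the one combination that would show whether the two single steps add up.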